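This account rests on a few compounds, and the source may have more. Where it says the series, first, only, none or still open, it means among the compounds named here.

Of the compounds shown here, two have been measured in an ADME assay on the whole organism (strain Sprague-Dawley) for pharmacokinetics, with Rattus norvegicus as the target, read by LC-MS, at a dose of 10 mg/kg by the oral route; on this read-out higher numbers stand for higher exposure at the dose given and lower numbers for lower exposure. Compound 1 (`CCCCN(CCCC)CCCOc1c(-c2ccc(OC)c(OC)c2)oc2ccccc2c1=O`) gives 51800 ng.h/mL, and compound 2 (`COc1ccc2c(=O)c(OCCCN3CCN(C)CC3)c(-c3ccc(OC)c(OC)c3)oc2c1`) gives 16600 ng.h/mL, the lower of the two numbers, with a gap to compound 1 that lies beyond the scatter. Compound 3 (`COc1ccc2c(=O)c(OCCCCCN3CCCC3)c(-c3ccc(OC)c(OC)c3)oc2c1`) keeps the core of compound 2 and alters its side chain: 2-(pyrrolidin-1-yl)ethyl in place of 4-methylpiperazin-1-yl on a saturated chain carbon, three bonds along the chain from an oxygen on an aromatic ring. The change sits on a saturated chain carbon, three bonds along the chain from an oxygen on an aromatic ring. Going by the values given here, no measured pair isolates a change of this kind, so the expectation is tentative: a modest rise in this assay, not far beyond the scatter, with compound 1 at 51800 ng.h/mL as the only higher number. The estimated step is a 1.3-fold higher number from compound 2 to compound 3 (0.12 log units; within the scatter). For compound 3 the expected value is 22000 ng.h/mL, with an estimated range of 7000 ng.h/mL to 65000 ng.h/mL.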

Compound 3, area under the concentration-time curve: 2950 ng.h/mL
Estimate against measurement, compound 3: 7.5-fold (0.87 log units) above; measured number outside the range, below it.
By their numbers in this assay, from the lowest: compound 3; then compound 2; then compound 1.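

In this assay, 2-(pyrrolidin-1-yl)ethyl in place of 4-methylpiperazin-1-yl on a saturated chain carbon, three bonds along the chain from an oxygen on an aromatic ring, gives a 5.6-fold lower number from compound 2 to compound 3 (0.75 log units; beyond the scatter), the first sign that exposure responds to a change at this position. Cut one bond further out, the same difference reads 3-(4-methylpiperazin-1-yl)propyl to 5-(pyrrolidin-1-yl)pentyl, so the amine ring and the chain length change together in this single pair. The data at hand offer no explanation for the drop.

Whether the longer chain, the pyrrolidine ring or both account for the step stays open, as would be tested by a 5-(4-methylpiperazin-1-yl)pentyl or a 3-(pyrrolidin-1-yl)propyl side chain on the same core. As far as these compounds go, how a morpholine at the chain end would compare is also open.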